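Taking the benzoyl group off compound 1

A few compounds are considered here, and "the series" means these few. Any claim that something is new, unique, unknown or untested is made for them only; others in the source may bear on it.

In a functional assay on T47D cells (Homo sapiens) for cytotoxicity, read by MTT assay, with a stated time of 48 h (a higher number here means a weaker inhibitor, a lower number a stronger inhibitor), compound 1 `O=C(O[C@H]1C[C@H](n2cc(F)c(=O)[nH]c2=O)O[C@@H]1COP(=O)(O)Oc1ccc2ncccc2c1)c1ccccc1` gives 7140 nM and sits at the low end of the three measured numbers. Compound 2 `CCOC(=O)C[n+]1cccc(OP(=O)([O-])OC[C@H]2O[C@@H](n3cc(F)c(=O)[nH]c3=O)C[C@@H]2OC(=O)c2ccccc2)c1` gives 12700 nM and stays within the usual scatter of compound 1. Compound 3 `CCOC(=O)C[n+]1cccc2cc(OP(=O)([O-])OC[C@H]3O[C@@H](n4cc(F)c(=O)[nH]c4=O)C[C@@H]3OC(=O)c3ccccc3)ccc21` gives 21600 nM and lies beyond that scatter, at a higher number than compound 1. Compound 4 `O=c1[nH]c(=O)n([C@H]2C[C@H](O)[C@@H](COP(=O)(O)Oc3ccc4ncccc4c3)O2)cc1F` has not been measured yet. It carries hydrogen in place of benzoyl on an oxygen on a saturated carbon. Going by the values given here, no measured pair of compounds shows this change, so the expectation is a loose one. The expected 1.4-fold lower number from compound 1 to compound 4 (0.15 log units; within the scatter) in this assay is small, toward a lower number and within the scatter. Compound 4 is expected at 5000 nM (estimated range 1200 nM to 20000 nM).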

Compound 4, half-maximal inhibitory concentration: 8110 nM
For compound 4 the middle estimate is 1.6-fold (0.21 log units) below the measured one, within the range that was stated.
By their numbers in this assay, from the lowest: compounds 1, 4, 2 and 3 (each within the scatter of the next, the first and the last beyond it).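

Swapping benzoyloxy for hydroxy on the saturated carbon gives, in this assay, only a 1.1-fold higher number from compound 1 to compound 4 (0.06 log units; within the scatter) and so leaves the two compounds indistinguishable. At this position, the whole benzoyl group, aromatic ring included, can go without a readable change in this cytotoxicity measure. No outside evidence bears on why the two compounds match.

As far as these compounds go, whether a smaller acetyl ester or a longer chain ester on that oxygen would read the same remains open, as does an amine in place of the hydroxy.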